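Adding a Fluorine to a Chlorophenyl Anilinoquinazoline Series

This account rests on a few compounds, and the source may have more. Where it says the series, first, only, none or still open, it means among the compounds named here.

Of the compounds shown here, three sharing one core have been measured in a functional assay on PC-3 cells (Homo sapiens) for inhibition, read by MTT assay, with a stated time of 72 h; on this read-out lower numbers stand for stronger inhibition and higher numbers for weaker inhibition. Compound 1 `C=CC(=O)Nc1cccc(NC(=O)CSc2nc(Nc3ccccc3F)c3ccccc3n2)c1` gives 9340 nM. Compound 2 `C=CC(=O)Nc1cccc(NC(=O)CSc2nc(Nc3ccccc3Br)c3ccccc3n2)c1` gives 17100 nM, and compound 3 `C=CC(=O)Nc1cccc(NC(=O)CSc2nc(Nc3ccc(Cl)cc3)c3ccccc3n2)c1` gives 10800 nM. Compound 3 stands second highest of the three numbers, but every gap separating it from the others lies within the scatter: a 1.2-fold higher number from compound 1 to compound 3 (0.06 log units; within the scatter) and a 1.6-fold lower number from compound 2 to compound 3 (0.20 log units; within the scatter). The only other comparison among these compounds, a 1.8-fold higher number from compound 1 to compound 2 (0.26 log units; within the scatter), is likewise within the scatter.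

Compound 4 `C=CC(=O)Nc1cccc(NC(=O)CSc2nc(Nc3ccc(F)c(Cl)c3)c3ccccc3n2)c1` has not yet been measured. The change from compound 3 is 3-chloro-4-fluorophenyl in place of 4-chlorophenyl on a nitrogen on an aromatic ring. None of the three measured steps is this change; the nearest are the exchange of the halogen on the phenyl between compound 1 and compound 2 and the move to a different halophenyl from compound 1 or compound 2 to compound 3, all of which stayed within the scatter. On this basis no step beyond the scatter is expected in this assay for compound 4, and its estimated step is a 1.1-fold lower number from compound 3 to compound 4 (0.03 log units; within the scatter). Compound 4 is therefore expected to give about 10000 nM, with a likely range from 4500 nM to 22000 nM.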

Compound 4, half-maximal inhibitory concentration: > 50000 nM
Compound 4 ended at the assay's limit; the forecaster's own chance of this, stated with the estimate: 5%; middle value at least 5.0-fold (0.69 log units) from the limit.
By their numbers in this assay, from the lowest: compounds 1, 3 and 2 (each within the scatter of the next). At a limit, above all of these: compound 4.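

In this assay, among these compounds, the halophenyl on the nitrogen on an aromatic ring had so far been exchanged with no step beyond the scatter, and the change to 3-chloro-4-fluorophenyl is the first at this place to give one, with an at least 4.6-fold higher number from compound 3 to compound 4 (0.66 log units; beyond the scatter). The other two comparisons agree, with an at least 2.9-fold higher number from compound 2 to compound 4 (0.46 log units; beyond the scatter) and an at least 5.3-fold higher number from compound 1 to compound 4 (0.72 log units; beyond the scatter), so compound 4 stands apart from compounds 1, 2 and 3, which remain within the scatter of one another. The reading for compound 4 is a limit of the assay and not a number, and all three steps are read against it: the limit of > 50000 nM in this assay, at which 1 of the 4 values shown sits.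

On these data alone, whether the step goes with the added fluorine or with the chlorine's place stays open, as the change alters both at once, and a 3-chlorophenyl or a 4-fluorophenyl on the same nitrogen would separate the two. A plain phenyl or a 4-methoxyphenyl at that place would show how far this result depends on halogen on the ring at all.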